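The source may report more compounds than this note shows. Statements on the series, on what has been measured and on what is new or still open speak of the compounds shown alone.

In a functional assay on CHO-K1 cells for antagonist activity at transient receptor potential cation channel subfamily V member 1 (Homo sapiens), read by FLIPR; on this read-out lower numbers stand for stronger inhibition and higher numbers for weaker inhibition:
compound 1 `CC(C(=O)NCc1ccc(C(F)(F)F)nc1Nc1ccc(F)cc1)c1ccc(NS(C)(=O)=O)c(F)c1` gives 39.2 nM
compound 2 `CC(C(=O)NCc1ccc(C(F)(F)F)nc1NCc1ccccc1)c1ccc(NS(C)(=O)=O)c(F)c1` gives 15.8 nM

Among the compounds with values here, compound 2 stands at the lowest of the two numbers so far in this assay; its nearest neighbour is compound 1, and the one step that has been measured, a 2.5-fold lower number from compound 1 to compound 2 (0.39 log units; beyond the scatter), separates them. Within the data shown here, that step, replacing 4-fluorophenyl on the ring nitrogen's substituent with benzyl, is the only change in this region that has a number behind it.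

The next compound, compound 3 `CC(C(=O)NCc1ccc(C(F)(F)F)nc1N(C)C)c1ccc(NS(C)(=O)=O)c(F)c1`, differs from compound 2 as follows: dimethylamino in place of benzylamino on an aromatic carbon. This change goes further than the measured step. Compound 1 and compound 2 both keep an aromatic ring on that nitrogen and differ in how it is attached; compound 3 keeps no ring there at all and loses the hydrogen-bond donor. Among the measured compounds shown here, no measured step therefore speaks to this change directly, and the one measured step bears on it only loosely, in that the character of the group on this nitrogen does move the number in this assay beyond the scatter.

Given this, a step in this assay towards a higher number is expected, and the estimate for compound 3 is 60 nM, with a range from 15 nM to 250 nM; the expected step is a 3.8-fold higher number from compound 2 to compound 3 (0.58 log units; beyond the scatter).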

Compound 3, inhibition constant: 19.1 nM
For compound 3 the middle estimate is 3.1-fold (0.50 log units) above the measured one; the range from low to high includes it.
By their numbers in this assay, from the lowest: compounds 2 and 3 (each within the scatter of the next); then compound 1.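

In this assay, dimethylamino stands in place of benzylamino with a 1.2-fold higher number from compound 2 to compound 3 (0.08 log units; within the scatter) as the step, so at this carbon, next to the ring nitrogen, the number stays level with that of the benzylamino compound even though the six-membered aromatic ring and the hydrogen-bond donor are both gone. Set against (4-fluorophenyl)amino, dimethylamino gives a 2.1-fold lower number from compound 1 to compound 3 (0.31 log units; beyond the scatter) as a modest step, so among these three compounds a ring on this nitrogen is not required for the lower numbers, and compound 1, which carries such a ring, is the one that stands apart from the other two. Within the data shown here, nothing measured so far accounts for this result.

Dimethylamino removes the ring and the donor in a single change, so the compounds shown do not separate what each contributes; methylamino, which would keep a donor without a ring, and N-methyl-N-benzylamino, which would keep the ring without a donor, would pull the two apart. Also open, as far as these compounds go, is how far this tolerance extends, for example to a cyclic amine such as pyrrolidine or morpholine, or to a longer chain such as phenethylamino.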